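A few compounds are considered here, and "the series" means these few. Any claim that something is new, unique, unknown or untested is made for them only; others in the source may bear on it.

In a functional assay on cells (Leukemia cell, Homo sapiens) for cytotoxicity, read by sulforhodamine B assay, with a stated time of 48 h (on this read-out higher numbers stand for weaker inhibition of growth and lower numbers for stronger inhibition of growth), three compounds built on one shared core have been measured. Compound 1 `O=C1N=C(N2N=C(c3ccccc3)CC2c2ccccc2O)S/C1=C1/C(=O)Nc2ccc(Br)cc21` gives 1050 nM. Compound 2 `COc1ccc(C2CC(c3ccccc3)=NN2C2=NC(=O)/C(=C3\C(=O)Nc4ccccc43)S2)cc1` gives 20800 nM. Compound 3 `COc1ccc(C2CC(c3ccccc3)=NN2C2=NC(=O)/C(=C3\C(=O)Nc4ccc(Br)cc43)S2)cc1` gives 4230 nM, the second highest of the three numbers. Its nearest neighbour is compound 1, with a 4.0-fold higher number from compound 1 to compound 3 (0.61 log units; beyond the scatter) for the swap of 4-methoxyphenyl for 2-hydroxyphenyl on a saturated ring carbon. Its furthest neighbour is compound 2, with a 4.9-fold lower number from compound 2 to compound 3 (0.69 log units; beyond the scatter) for bromo in place of hydrogen on an aromatic carbon.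

Compound 4 `COc1ccc(C2CC(c3ccc4ccccc4c3)=NN2C2=NC(=O)/C(=C3\C(=O)Nc4ccc(Br)cc43)S2)cc1` is not yet measured. It differs from compound 3 in one place: naphthalen-2-yl in place of phenyl on a carbon with a double bond to nitrogen. Among the measured compounds shown here, neither of the two measured steps touches this carbon, so no measured step bears directly on the change; both steps altered other parts of the core and were only modest in size. With nothing in the data pointing one way or the other, the step from compound 3 to compound 4 is expected to stay close to the scatter, a 1.1-fold lower number from compound 3 to compound 4 (0.02 log units; within the scatter). Compound 4 is therefore estimated at 4000 nM in this assay, with a range from 1300 nM to 12000 nM that allows for a wider swing in either direction.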

Compound 4, concentration for total growth inhibition: 3370 nM
The estimate for compound 4 lay 1.2-fold (0.07 log units) above the measured number, and the stated range covers the measured number.
By their numbers in this assay, from the lowest: compound 1; then compounds 4 and 3 (each within the scatter of the next); then compound 2.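

Among the compounds shown here, this is the first measured change at the carbon with a double bond to nitrogen: in this assay, naphthalen-2-yl, with 10 heavy atoms and 2 aromatic rings, replaces phenyl, with 6 heavy atoms and one aromatic ring, and gives a 1.3-fold lower number from compound 3 to compound 4 (0.10 log units; within the scatter) with the rest of compound 3 unchanged. So, for this pair, adding a second aromatic ring here leaves the read-out within the usual scatter, whereas the two earlier single changes elsewhere on the shared core both fell beyond it (a 4.0-fold higher number from compound 1 to compound 3 (0.61 log units; beyond the scatter); a 4.9-fold lower number from compound 2 to compound 3 (0.69 log units; beyond the scatter)). No supporting measurement is available to explain this result.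

The compounds shown leave open whether this carbon would accept groups of another kind, such as a small methyl group, or a phenyl ring carrying an amine or a carboxylic acid. They also leave open whether the same swap would give a similar result with 2-hydroxyphenyl on the saturated ring carbon or with hydrogen in place of the bromo group.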